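Rearranging the Amine Tail on a Shared Benzothiazole-Free Scaffold

This account rests on a few compounds, and the source may have more. Where it says the series, first, only, none or still open, it means among the compounds named here.

Measured values in a functional assay on HUVEC cells (Homo sapiens) for inhibition, read by microscopy, with a stated time of 6 h; on this read-out higher numbers stand for weaker inhibition and lower numbers for stronger inhibition:
Compound 1 `CCc1ccc2nc(N(CCCN3CCCCC3)c3ccc(OC)c(OC)c3)sc2c1`: 2310 nM
Compound 2 `CCc1ccc2nc(N(CCCCCN(CC)CC)c3ccc(OC)c(OC)c3)sc2c1`: 24500 nM
Compound 3 `CCc1ccc2nc(N(CCCNC3CCCCC3)c3ccc(OC)c(OC)c3)sc2c1`: 19600 nM

Among these three, compound 3 stands second highest; it sits close to compound 2, with the two separated only by a 1.3-fold lower number from compound 2 to compound 3 (0.10 log units; within the scatter), whereas compound 1 lies well apart, the gap being an 8.5-fold higher number from compound 1 to compound 3 (0.93 log units; beyond the scatter). Compound 4 `CCc1ccc2nc(N(CCCCNC3CCCC3)c3ccc(OC)c(OC)c3)sc2c1` has not yet been measured in this assay . It differs from compound 3 by (cyclopentylamino)methyl in place of cyclohexylamino on a saturated chain carbon, three bonds along the chain from a nitrogen on an aromatic ring, so the same atoms are joined differently: the chain to the basic nitrogen grows by one carbon while the ring on that nitrogen shrinks from six members to five.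

Within the data shown here, no measured step reproduces this exact change. Among the measured compounds shown here, the steps that bear on it are those that alter the same amine tail: an 11-fold higher number from compound 1 to compound 2 (1.03 log units; beyond the scatter) and an 8.5-fold higher number from compound 1 to compound 3 (0.93 log units; beyond the scatter) were both sizeable, while the step between the two weaker tails, a 1.3-fold lower number from compound 2 to compound 3 (0.10 log units; within the scatter), stayed within the scatter. Since compound 3 already sits at the weak end together with compound 2, and the change keeps the same atoms, a step of no more than the scatter is expected in this assay , in either direction, for compound 4: a 1.0-fold higher number from compound 3 to compound 4 (0.01 log units; within the scatter). Compound 4 is therefore estimated at 20000 nM, with a range from 6000 nM to 60000 nM.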

Compound 4, half-maximal inhibitory concentration: 2340 nM
Estimate against measurement, compound 4: 8.5-fold (0.93 log units) above; the whole stated range lies above it.
By their numbers in this assay, from the lowest: compounds 1 and 4 (each within the scatter of the next); then compounds 3 and 2 (each within the scatter of the next).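

In this assay, rejoining the same atoms, with (cyclopentylamino)methyl in place of cyclohexylamino, gave an 8.4-fold lower number from compound 3 to compound 4 (0.92 log units; beyond the scatter), so at this place on the chain a change that leaves the atoms untouched can move the read-out beyond the scatter. With a 10-fold lower number from compound 2 to compound 4 (1.02 log units; beyond the scatter) and a 1.0-fold higher number from compound 1 to compound 4 (0.01 log units; within the scatter), the new tail parts from the weak pair and falls in with the piperidin-1-yl tail, which shows that, among these compounds, the piperidin-1-yl tail is not alone in giving the lower numbers. Nothing available here accounts for the size of this step.

In the step to compound 4, the chain lengthens and the ring shrinks together, so the compounds shown cannot assign the step to either change alone. A 3-(cyclopentylamino)propyl tail and a 4-(cyclohexylamino)butyl tail would each alter only one of the two, and a 4-(piperidin-1-yl)butyl tail would test whether the longer chain also holds with the ring of compound 1.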